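Halogen swap on the benzyl ether of the pyrazole acid series

The compounds below may be only part of what the source reports. "The series", "measured", "known", "first", "only" and "open" are said of these compounds alone.

Measured so far:
compound 1 `Cc1cc(C(=O)O)nn1Cc1cc(Br)ccc1OCc1ccc(F)cc1F` gives 2.63 nM
compound 2 `Cc1cc(C(=O)O)nn1Cc1cc(Cl)ccc1OCc1ccc(Cl)cc1Cl` gives 0.55 nM

Both numbers come from a functional assay on CHO-K1 cells for antagonist activity at prostaglandin E2 receptor EP1 subtype (Homo sapiens), read by FLIPR; a lower number here means a stronger inhibitor, a higher number a weaker inhibitor. Within the data shown here, compound 2 stands lowest of the two, with compound 1 its only neighbour and a gap between them that lies beyond the scatter. Among the measured compounds shown here, compound 1 and compound 2 differ in two places at once, so their values show only that the pair with the 2,4-dichlorobenzyl ether and the chlorine on the core reads lower than the pair with the 2,4-difluorobenzyl ether and the bromine.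

Compound 3 `Cc1cc(C(=O)O)nn1Cc1cc(Cl)ccc1OCc1ccc(F)cc1F` has not yet been measured. It keeps the chlorine on the core of compound 2 and carries 2,4-difluorophenyl in place of 2,4-dichlorophenyl on a saturated chain carbon bound to an oxygen on an aromatic ring. For the measured compounds named here, no measured pair isolates this change. Compound 3 is expected to weaken, with a step of a 3.6-fold higher number from compound 2 to compound 3 (0.56 log units; beyond the scatter) that reaches beyond the scatter, because compound 1 with the same difluorobenzyl group gives 2.63 nM. Compound 3 is estimated at 2 nM, within a range of 0.8 nM to 6 nM.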

Compound 3, inhibition constant: 1.12 nM
Estimate against measurement, compound 3: 1.8-fold (0.25 log units) above, and the stated range covers the measured number.
By their numbers in this assay, from the lowest: compound 2; then compound 3; then compound 1.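

In this assay, 2,4-difluorophenyl in place of 2,4-dichlorophenyl on a saturated chain carbon bound to an oxygen on an aromatic ring gives a 2.0-fold higher number from compound 2 to compound 3 (0.31 log units; beyond the scatter), which sizes this change on its own as a modest one with the chlorine on the core held fixed. With the 2,4-difluorobenzyl group held fixed, chloro in place of bromo on an aromatic carbon gives a 2.3-fold lower number from compound 1 to compound 3 (0.37 log units; beyond the scatter), so the gap between compound 1 and compound 2 now resolves into two single-place steps, each modest. Nothing available here accounts for either step.

Still open, as far as these compounds go, is how 2,4-dichlorobenzyl would read when paired with bromo on the core. The compounds shown also leave open how a 2,4-dimethylbenzyl group on the ether, or a nitrile in place of the halogen on the core, would read.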